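This account rests on a few compounds, and the source may have more. Where it says the series, first, only, none or still open, it means among the compounds named here.

Compound 1 `Nc1nc2cc(Cl)c(Cl)cc2n1Cc1ccccc1` gives 170000 nM in a functional assay on KB cells (Homo sapiens) for inhibition; a higher number here means a weaker inhibitor, a lower number a stronger inhibitor.
Compound 2 `COc1ccc(Cn2c(N)nc3cc(Cl)c(Cl)cc32)cc1` gives 45000 nM.

Compound 1 stands at the highest of the two numbers; its nearest neighbour is compound 2, reached by a 3.8-fold lower number from compound 1 to compound 2 (0.58 log units; beyond the scatter). Compound 3 `Cc1cccc(Cn2c(N)nc3cc(Cl)c(Cl)cc32)c1` carries methyl in place of hydrogen on an aromatic carbon. Among the compounds with values here, the only measured step that bears on this change is a 3.8-fold lower number from compound 1 to compound 2 (0.58 log units; beyond the scatter), a modest shift from a different group on an aromatic carbon. Methyl is not methoxy, so the step from compound 1 to compound 3 is expected to be small, toward a lower number if beyond the scatter at all. Compound 3 is therefore estimated at 100000 nM, within 40000 nM to 250000 nM, an expected step of a 1.7-fold lower number from compound 1 to compound 3 (0.23 log units; within the scatter).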

Compound 3, half-maximal inhibitory concentration: 65000 nM
Estimate against measurement, compound 3: 1.5-fold (0.19 log units) above, and the stated range covers the measured number.
By their numbers in this assay, from the lowest: compounds 2 and 3 (each within the scatter of the next); then compound 1.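

A single methyl on an aromatic carbon of the six-membered ring of carbon only, meta to a large group, is enough to give a 2.6-fold lower number from compound 1 to compound 3 (0.42 log units; beyond the scatter) and so a shift beyond the scatter. A lower number on this ring is therefore not tied to methoxy alone, since methyl, with 0 hydrogen-bond acceptors, also gives one. Nothing measured here accounts for this shift.

As far as these compounds go, whether chlorine, an amine, a carboxylic acid or a longer chain at this carbon would lower the number further remains open. So does whether two such groups on this ring would add up.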